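The source may report more compounds than this note shows. Statements on the series, on what has been measured and on what is new or still open speak of the compounds shown alone.

Compound 1 `COc1ccc(/C(Cl)=C/C=C(\C#N)C(=O)c2c(C)[nH]c3ccccc23)cc1`, compound 2 `COc1cc(/C(Cl)=C/C=C(\C#N)C(=O)c2c[nH]c3ccc(Br)cc23)cc(OC)c1OC` and compound 3 `Cc1[nH]c2ccccc2c1C(=O)/C(C#N)=C/C=C(\Cl)c1ccc(Br)cc1` were examined in a functional assay for inhibition, with a stated time of 5 min, tested at 1 mM; a lower number here means less inhibition, a higher number more inhibition at the concentration tested (going by the name of the read-out). Compound 1 gives 63.1%, compound 2 gives 50%, and compound 3 gives 69.1%; compound 2 stands lowest of the three, its gaps to compound 1 and compound 3 both beyond the scatter. Between compound 3 and compound 1 the structural change is methoxy in place of bromo on an aromatic carbon and the step is a number 6 percentage points lower from compound 3 to compound 1 (within the scatter). Compound 4 `COc1ccc2[nH]cc(C(=O)/C(C#N)=C/C=C(\Cl)c3cc(OC)c(OC)c(OC)c3)c2c1` has not yet been measured. It differs from compound 2 by methoxy in place of bromo on an aromatic carbon, the same kind of change, although here the place lies on a fused or bridged system of two rings, meta to a fused ring and para to a fused ring, whereas before it was para to a large group. The difference between the cores of compound 2 and compound 3 is not broken down here. Resting on the step of a number 6 percentage points lower from compound 3 to compound 1 (within the scatter), the expected step in this assay is a number 3 percentage points lower from compound 2 to compound 4 (within the scatter). Compound 4 is accordingly estimated at 47%.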

Compound 4, a percentage reported as inhibition, at one concentration (the size of the read-out at that concentration, not a potency): 50%
Compound 4: middle estimate off by 3 percentage points, on the low side, and the stated range covers the measured number.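

Placing methoxy in place of bromo on an aromatic carbon of the core of compound 2 gives, in this assay, no change at the digits printed from compound 2 to compound 4 (within the scatter). Set beside the earlier case, the change reads alike on both cores: the same change on two cores in this assay, a number 6 percentage points lower (within the scatter) from compound 3 to compound 1 and no change at the digits printed (within the scatter) from compound 2 to compound 4, 6 percentage points apart, within the scatter of two such steps This agreement rests on only two pairs, with the change sitting at a different place on each, and on a single tested concentration, so it does not show that bromo and methoxy are interchangeable in potency or that the result would hold on any further core. The compounds shown leave open how an amine or a carboxylic acid at this place would read. They also leave open whether any group there would give a step beyond the scatter.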